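Swapping the chain amine: from dimethylamino to piperidine

The compounds below may be only part of what the source reports. "The series", "measured", "known", "first", "only" and "open" are said of these compounds alone.

Compound 1 `CN1CCN(CCN(C)c2ccc(Cn3c(=O)[nH]c4c(N)nc(C(F)(F)F)cc43)cn2)CC1`: 0.7 10^-6 cm/s
Compound 2 `CN(C)CCNc1ccc(Cn2c(=O)[nH]c3c(N)nc(C(F)(F)F)cc32)cn1`: 0.1 10^-6 cm/s

For the measured compounds named here, in an ADME assay for permeability, using PAMPA (a higher number here means that the compound crosses the layer faster, a lower number that the compound crosses the layer more slowly), compound 2 gives the lower of the two numbers, with compound 1 the only neighbour, separated by a 7.0-fold lower number from compound 1 to compound 2 (0.85 log units; beyond the scatter). Compound 3 `Nc1nc(C(F)(F)F)cc2c1[nH]c(=O)n2Cc1ccc(NCCN2CCCCC2)nc1` differs from compound 2 by piperidin-1-yl in place of dimethylamino on a saturated chain carbon, two bonds along the chain from a nitrogen on an aromatic ring. Going by the values given here, the one measured step also altered this chain amine, and it was modest; the new change is smaller in kind, so a modest step upward is expected, a 3.0-fold higher number from compound 2 to compound 3 (0.48 log units; beyond the scatter), staying within reach of the scatter. Compound 3 is therefore estimated at 0.3 10^-6 cm/s, with a range from 0.1 10^-6 cm/s to 0.9 10^-6 cm/s.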

Compound 3, apparent permeability: 0.3 10^-6 cm/s
Estimate against measurement, compound 3: no gap at the digits printed; measured number inside the range.
By their numbers in this assay, from the lowest: compound 2; then compound 3; then compound 1.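

In this assay the amine at the end of the chain matters on its own: piperidin-1-yl in place of dimethylamino, with nothing else changed, gives a 3.0-fold higher number from compound 2 to compound 3 (0.48 log units; beyond the scatter) and so separates two otherwise identical structures. Against the larger methyl(2-(4-methylpiperazin-1-yl)ethyl)amino side chain, the step is a 2.3-fold lower number from compound 1 to compound 3 (0.37 log units; beyond the scatter) so this swap alone does not close that gap. Nothing available explains either step.

Still open, from the compounds shown here alone, is where morpholin-4-yl on the same saturated chain carbon would fall, and what a longer chain carrying piperidin-1-yl would read.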